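The source may hold more compounds than are shown below. What is called first, only, known or untested is meant among the compounds shown, and "the series" means these compounds.

Measured so far:
compound 1, `NC(=S)N/N=C(\COc1ccc(F)cc1)c1ccc(Br)cc1`, 52300 nM
compound 2, `NC(=S)N/N=C(\COc1ccc(F)c(Cl)c1)c1ccc(Br)cc1`, 48000 nM
compound 3, `NC(=S)N/N=C(\COc1cccc(Cl)c1)c1ccc(Br)cc1`, a limit of < 50200 nM

All three were tested in an ADME assay on L929 cells (Mus musculus) for cytotoxicity, read by resazurin assay, with a stated time of 96 h; a lower number here means that less compound is tolerated, a higher number that more compound is tolerated. Compound 1 gives 52300 nM there, and compound 2 gives 48000 nM. For compound 3 only a limit is known, < 50200 nM. Compound 2 differs from compound 1 by chloro in place of hydrogen on an aromatic carbon, and that change gave a 1.1-fold lower number from compound 1 to compound 2 (0.04 log units; within the scatter). The cores of compound 1 and compound 3 differ by 3-chlorophenyl in place of 4-fluorophenyl on an oxygen on a saturated carbon, which gave an at least 1.0-fold lower number from compound 1 to compound 3 (0.01 log units; that floor lies within the scatter). From compound 2 to compound 3 the record shows a step that the limit leaves unreadable from compound 2 to compound 3, as the limit of < 50200 nM in this assay, at which 1 of the 3 values shown sits, hides the size.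

Compound 4, `NC(=S)N/N=C(\COc1cccc(Cl)c1Cl)c1ccc(Br)cc1`, has not yet been measured. It differs from compound 3 by chloro in place of hydrogen on an aromatic carbon, the same kind of change as from compound 1 to compound 2, though the surroundings differ: here the entering chloro sits ortho to a chloro group and ortho to a large group, whereas in compound 2 it sits ortho to a fluoro group and meta to a large group. Resting on a 1.1-fold lower number from compound 1 to compound 2 (0.04 log units; within the scatter), an expected step that the limit leaves unreadable from compound 3 to compound 4 follows. Compound 4 is estimated at 40000 nM, with a range from 12000 nM to 80000 nM.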

Compound 4, half-maximal cytotoxic concentration: 23100 nM
Beside the measured number, compound 4's estimate is 1.7-fold (0.24 log units) above it, within the range that was stated.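

The size of the step from compound 3 to compound 4 cannot be read, because compound 3 has only a limit, not a number: the limit of < 50200 nM in this assay, at which 1 of the 4 values shown sits. The compounds shown leave open how much chloro in place of hydrogen at this place changes the number in this assay, and whether that change matches the one seen from compound 1 to compound 2.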